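The compounds below may be only part of what the source reports. "The series", "measured", "known", "first", "only" and "open" are said of these compounds alone.

Among the measured compounds shown here, compound 1 (`CC(C)Cc1ccc(C(C)C(=O)NCc2ccc(Cl)cc2)cc1`) gives 27000 nM in an assay on brain for inhibition of Fatty-acid amide hydrolase 1 (Rattus norvegicus), read by scintillation counting, with a stated time of 10 min (a higher number here means a weaker inhibitor, a lower number a stronger inhibitor), one of only two numbers seen so far, and they sit within the scatter of each other. Compound 2 (`CC(C)Cc1ccc(C(C)C(=O)NCc2ccc(C(C)(C)C)cc2)cc1`) gives 25000 nM in this assay, so the step of a 1.1-fold lower number from compound 1 to compound 2 (0.03 log units; within the scatter) tells of no real shift. Compound 3 (`CC(C)Cc1ccc(C(C)C(=O)NCc2ccc(Cl)cc2Cl)cc1`) differs from compound 1 by chloro in place of hydrogen on an aromatic carbon. For the measured compounds named here, no measured step concerns this change; the single step seen changed a different group and stayed within the scatter, so nothing beyond the scatter is expected in this assay. Compound 3 is therefore estimated at 20000 nM, between 8000 nM and 50000 nM, an expected step of a 1.4-fold lower number from compound 1 to compound 3 (0.13 log units; within the scatter).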

Compound 3, half-maximal inhibitory concentration: 21000 nM
Beside the measured number, compound 3's estimate is 1.1-fold (0.02 log units) below it; measured number inside the range.
By their numbers in this assay, from the lowest: compounds 3, 2 and 1 (each within the scatter of the next).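

The second chloro, which turns 4-chlorophenyl into 2,4-dichlorophenyl, gives a 1.3-fold lower number from compound 1 to compound 3 (0.11 log units; within the scatter) in this assay. The place ortho to a large group therefore takes this added chloro with no real shift, whereas the earlier step changed a different place on the ring. No measurement here gives a reason for this flat result.

As far as these compounds go, whether an amine, a hydroxyl or a carboxylic acid at this place would move the number beyond the scatter stays open. The compounds shown also leave open whether any change to the shared core would do so.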